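The source may report more compounds than this note shows. Statements on the series, on what has been measured and on what is new or still open speak of the compounds shown alone.

Working notes on the ester series. Three members have numbers in an assay on NIH3T3 cells with Urotensin-2 receptor (Homo sapiens) as the target; a lower number here means a smaller maximal response, a higher number a larger maximal response: compound 1 `CN(C)CCC(OC(=O)c1cn(C)c2ccccc12)c1ccc(Cl)cc1`, compound 2 `COc1ccc(C(=O)OC(CCN(C)C)c2ccc(Cl)cc2)cc1` and compound 3 `CN(C)CCC(OC(=O)c1ccc(-c2ccccc2)cc1)c1ccc(Cl)cc1`. In this assay compound 1 gives 104%, compound 2 gives 84% and compound 3 gives 53%. Among the measured compounds shown here, compound 2 therefore stands second of the three: compound 1 sits above it beyond the scatter, and the one single-point step in the set, a number 31 percentage points lower from compound 2 to compound 3 (beyond the scatter), runs downward from it beyond the scatter.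

Compound 4 `Cc1ccc(C)c(C(=O)OC(CCN(C)C)c2ccc(Cl)cc2)c1` is not yet measured. It differs from compound 2 in one place, (2,5-dimethylphenyl in place of 4-methoxyphenyl on a carbonyl carbon). For the measured compounds named here, the only measured step that bears on this position is a number 31 percentage points lower from compound 2 to compound 3 (beyond the scatter), where phenyl in place of methoxy cut the number sharply. Going by the values given here, whether two methyl groups on that ring behave like the methoxy of compound 2 or like the phenyl of compound 3 cannot be read from the data; a moderate drop is expected, smaller than the one to compound 3, with wide uncertainty. Compound 4 is thus estimated at 75% in this assay, with a range of 50% to 100%. This estimate amounts to an expected step of a number 9 percentage points lower from compound 2 to compound 4 (within the scatter).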

Compound 4, largest response reached (reported as efficacy), in percent of the reference or control that the assay uses: 86%
Estimate against measurement, compound 4: 11 percentage points below; the range from low to high includes it.
By their numbers in this assay, from the lowest: compound 3; then compounds 2 and 4 (each within the scatter of the next); then compound 1.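

At the group on the carbonyl carbon, 2,5-dimethylphenyl in place of 4-methoxyphenyl gives a number 2 percentage points higher from compound 2 to compound 4 (within the scatter) in this assay, so the hydrogen-bond acceptor of the leaving group can go, at an equal heavy-atom count, without a readable change in maximal response. Set beside a number 31 percentage points lower from compound 2 to compound 3 (beyond the scatter), this shows that a change at this place need not lower the number: the large drop seen with the phenyl group in compound 3 does not recur in compound 4. No measurement given here accounts for either outcome.

The compounds shown do not separate the contributions of the two methyl groups of compound 4, so a ring with a single methyl group remains to be compared. Also open, on these data alone, is whether an amine or a carboxylic acid on that ring would keep the number of compound 2 or lower it.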